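The source may hold more compounds than are shown below. What is called first, only, known or untested is meant among the compounds shown, and "the series" means these compounds.

Of the compounds shown here, three built on one shared core have been tested in a functional assay on PC-3 cells (Homo sapiens) for antiproliferative activity, read by MTT assay, with a stated time of 72 h; a lower number here means a stronger inhibitor, a higher number a weaker inhibitor. Compound 1 `C/C=C/C(=O)Nc1cc2c(N3CCc4ccccc43)ncnc2cc1OC` gives 8120 nM. Compound 2 `COc1cc2ncnc(N3CCCc4ccccc43)c2cc1NC(=O)C=C(C)C` gives 6130 nM. Compound 3 `C/C=C/C(=O)Nc1cc2c(N3CCCc4ccccc43)ncnc2cc1OC` gives 7520 nM, the second highest of the three numbers; its nearest neighbour is compound 1 and its furthest is compound 2, and both gaps lie within the scatter, so no ranking can be read among them. Compound 4 `CCC/C=C/C(=O)Nc1cc2c(N3CCCc4ccccc43)ncnc2cc1OC` has not yet been measured. It differs from compound 3 by ethyl in place of hydrogen on a saturated chain carbon bound to a double-bonded chain carbon, so that the (prop-1-en-1-yl)carbonyl of compound 3 becomes a (pent-1-en-1-yl)carbonyl. Within the data shown here, one measured step touches the same part of the molecule: a 1.2-fold higher number from compound 2 to compound 3 (0.09 log units; within the scatter) exchanged one small group on the carbonyl carbon for another, and the number barely moved. Among the measured compounds shown here, nothing measured here shows how a longer chain at this place behaves; the only guide is that altering the group on the carbonyl carbon produced no step beyond the scatter. The expected step is accordingly a 1.1-fold lower number from compound 3 to compound 4 (0.03 log units; within the scatter), small enough to stay within the scatter. Because a 1.2-fold higher number from compound 2 to compound 3 (0.09 log units; within the scatter) was so modest, compound 4 is estimated at 7000 nM, with a range from 2800 nM to 18000 nM.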

Compound 4, half-maximal inhibitory concentration: 2240 nM
Compound 4: the middle estimate sits 3.1-fold (0.49 log units) above what was measured; the measured number lies below the stated range.
By their numbers in this assay, from the lowest: compound 4; then compounds 2, 3 and 1 (each within the scatter of the next).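

In this assay, among these compounds, ethyl in place of hydrogen on a saturated chain carbon bound to a double-bonded chain carbon gives a 3.4-fold lower number from compound 3 to compound 4 (0.53 log units; beyond the scatter), the first step to go beyond the scatter. The same direction shows in a 2.7-fold lower number from compound 2 to compound 4 (0.44 log units; beyond the scatter), whereas the exchange of 2-methylprop-1-en-1-yl for prop-1-en-1-yl gave only a 1.2-fold higher number from compound 2 to compound 3 (0.09 log units; within the scatter), so the group on this carbonyl carbon can change the number after all, even though the earlier pair suggested it made little difference. Nothing available bears on the cause of this modest gain.

Open, going by these compounds, is whether the number keeps falling with a longer chain such as hept-1-en-1-yl, levels off, or rises again, and whether a chain ending in an amine would fit the same trend. Among the compounds shown here, also open is whether pent-1-en-1-yl brings a similar step on the core of compound 1, since the change has been seen here on only one core.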